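Piperidinyl to ethylamino on the amide side chain

This account rests on a few compounds, and the source may have more. Where it says the series, first, only, none or still open, it means among the compounds named here.

Measured so far:
compound 1 `O=C(CC(CC(=O)NC1Cc2ccccc2C1)c1ccc(Cl)cc1)NCCN1CCCCC1` 89100 nM
compound 2 `CCN(C(=O)CC(CC(=O)NCCN1CCCCC1)c1ccc(Cl)cc1)C1Cc2ccccc2C1` 21200 nM

Compound 2 stands at the lower of the two numbers obtained in a functional assay on MGC-803 cells (Homo sapiens) for inhibition; on this read-out lower numbers stand for stronger inhibition and higher numbers for weaker inhibition. For the measured compounds named here, its neighbour is compound 1, and the single step on record, a 4.2-fold lower number from compound 1 to compound 2 (0.62 log units; beyond the scatter), is the only guide to how this series responds to structural change.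

Compound 3 `CCNCCNC(=O)CC(CC(=O)N(CC)C1Cc2ccccc2C1)c1ccc(Cl)cc1` is not yet measured. It differs from compound 2 as ethylamino in place of piperidin-1-yl on a saturated chain carbon, two bonds along the chain from an amide-type nitrogen. Going by the values given here, no measured step touches this part of the molecule: the step from compound 1 to compound 2 concerns the ethyl on the amide-type nitrogen, not the terminal amine of the chain. There is therefore no basis for expecting a shift beyond the scatter in this assay in either direction, and the working assumption is that the number for compound 3 stays close to that of compound 2, with the range kept wide to cover an untested change.

For compound 3 the expected result in this assay is 25000 nM, between 8000 nM and 80000 nM.

The step this implies is estimated as a 1.2-fold higher number from compound 2 to compound 3 (0.07 log units; within the scatter).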

Compound 3, half-maximal inhibitory concentration: 43800 nM
Beside the measured number, compound 3's estimate is 1.8-fold (0.24 log units) below it; the range from low to high includes it.
By their numbers in this assay, from the lowest: compound 2; then compound 3; then compound 1.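

The terminal amine of the chain now proves to be a position that responds in this assay: ethylamino in place of piperidin-1-yl gives a 2.1-fold higher number from compound 2 to compound 3 (0.32 log units; beyond the scatter), a modest step but one beyond the scatter, so this part of the molecule cannot be treated as neutral. Two differences travel together in this single change, since ethylamino has no ring and one hydrogen-bond donor, whereas piperidin-1-yl has a six-membered non-aromatic ring and no donor, and the step cannot be assigned to either one alone. Nothing on record accounts for the step.

Still open, on these data alone, is whether the ring or the donor matters more, a question that dimethylamino, which has no ring and no donor, or morpholin-4-yl, which keeps a six-membered ring, could help settle at this place on the chain. Also unresolved is how far the response depends on the chain that carries the terminal amine, which a longer chain would test, and whether the ethyl on the other amide-type nitrogen and the terminal amine act independently of each other.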